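This account rests on a few compounds, and the source may have more. Where it says the series, first, only, none or still open, it means among the compounds named here.

Of the compounds shown here, three built on a shared core have been measured in a functional assay on RAW264.7 cells (Mus musculus) for inhibition; a higher number here means a weaker inhibitor, a lower number a stronger inhibitor. Compound 1 `O=C1/C(=C/c2cccc(C(F)(F)F)c2)CCc2cc(O)ccc21` gives 180 nM. Compound 2 `O=C1/C(=C/c2ccccc2)CCc2ccc(O)cc21` gives 710 nM. Compound 3 `O=C1/C(=C/c2ccccc2C(F)(F)F)CCc2ccc(O)cc21` gives 1020 nM. Among the measured compounds shown here, the only step between two of them that differs in one place is a 1.4-fold higher number from compound 2 to compound 3 (0.16 log units; within the scatter). Compound 3 therefore sits within the scatter of compound 2, while compound 1 gives a number that lies beyond the scatter lower than compound 3.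

Compound 4 `O=C1/C(=C/c2ccccc2Br)CCc2ccc(O)cc21` differs from compound 3 by bromo in place of trifluoromethyl on an aromatic carbon. For the measured compounds named here, no measured pair shows this exchange of bromo for trifluoromethyl. Going by the values given here, the one step that touches this aromatic carbon, a 1.4-fold higher number from compound 2 to compound 3 (0.16 log units; within the scatter), stayed within the scatter, so the group at this carbon, whether trifluoromethyl or hydrogen, changed the number little. Bromo at the same carbon is therefore expected to leave the number close to that of compound 3, with no step beyond the scatter in either direction. The expected step is a 1.2-fold lower number from compound 3 to compound 4 (0.08 log units; within the scatter). Compound 4 is estimated at 850 nM in this assay, with a range from 350 nM to 2000 nM.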

Compound 4, half-maximal inhibitory concentration: 500 nM
Compound 4: middle estimate off by 1.7-fold (0.23 log units), on the high side; measured number inside the range.
By their numbers in this assay, from the lowest: compound 1; then compounds 4, 2 and 3 (each within the scatter of the next, the first and the last beyond it).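

In this assay, among the compounds shown here, the exchange on this aromatic carbon, ortho to a large group, gives what the earlier compounds did not show: a 2.0-fold lower number from compound 3 to compound 4 (0.31 log units; beyond the scatter) shows that the choice of group here can move the number, though only modestly. Bromo and hydrogen do not separate, since a 1.4-fold lower number from compound 2 to compound 4 (0.15 log units; within the scatter) stays within the scatter, so compound 3 and compound 4 differ from each other while neither differs from compound 2 beyond the scatter. Nothing available here accounts for this difference between bromo and trifluoromethyl.

From the compounds shown here alone, it remains open whether an amine or a carboxylic acid on this same carbon would carry the number beyond the scatter from compound 2. Also open, going by these compounds, is whether bromo and trifluoromethyl would differ in the same way on another carbon of this aromatic ring.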